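A few compounds are considered here, and "the series" means these few. Any claim that something is new, unique, unknown or untested is made for them only; others in the source may bear on it.

In an ADME assay for permeability, using PAMPA, at pH 7.4 (a lower number here means that the compound crosses the layer more slowly, a higher number that the compound crosses the layer faster), compound 1 (`O=C(Nc1ccc(F)c(-c2nc3ccccc3o2)c1)c1cc([N+](=O)[O-])ccc1Cl`) gives 366 10^-6 cm/s. Compound 2 (`O=C(Nc1ccc(-c2nc3ccccc3s2)cc1)c1cc([N+](=O)[O-])ccc1Cl`) gives no number at all: its result reads "below limit of detection" (no number reported). Compound 2 therefore has no exact place on the scale. The next compound, compound 3 (`O=C(Nc1ccc(-c2ccccc2)cc1)c1cc([N+](=O)[O-])ccc1Cl`), carries phenyl in place of 1,3-benzothiazol-2-yl on an aromatic carbon, para to a large group: phenyl in place of 1,3-benzothiazol-2-yl on an aromatic carbon. Within the data shown here, no two measured compounds differ in one place only, so no measured step shows how large this change might be. In this assay, a large upward step from compound 2 to a readable number is expected, although compound 3 may also give no number. Among the measured compounds shown here, the only number available is that of compound 1, at 366 10^-6 cm/s, and the expected result lies lower than that. For compound 3, the estimated value is 100 10^-6 cm/s, with an expected range from 5 10^-6 cm/s to 400 10^-6 cm/s.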

Compound 3, apparent permeability: 26 10^-6 cm/s
The estimate for compound 3 lay 3.8-fold (0.59 log units) above the measured number; the range from low to high includes it.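

In this assay compound 2 gives no number, so the change from compound 2 to compound 3 cannot be read as a step. From the compounds shown here alone, how far phenyl in place of 1,3-benzothiazol-2-yl shifts the read-out stays open. No measurement shown offers an explanation for this result.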